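This account rests on a few compounds, and the source may have more. Where it says the series, first, only, none or still open, it means among the compounds named here.

Of the compounds shown here, three have so far been measured in a functional assay on SW-620 cells (Homo sapiens) for cytotoxicity, read by sulforhodamine B assay, with a stated time of 48 h, tested at 0.1 uM; a higher number here means a weaker effect of the compound at the concentration tested, a lower number a stronger effect. Compound 1 `COc1ccc(-c2cc(/C=C/C(=O)c3ccc(N)cc3)[nH]n2)cc1` gives 101%, compound 2 `COc1cc(-c2cc(/C=C/C(=O)c3ccc(N)cc3)[nH]n2)cc(OC)c1OC` gives 95%, and compound 3 `COc1ccc(C(=O)/C=C/c2cc(-c3cc(OC)c(OC)c(OC)c3)n[nH]2)cc1OC` gives 99%. The number for compound 2 is the lowest of the three as written, yet neither the step of a number 4 percentage points higher from compound 2 to compound 3 (within the scatter) nor the gap to compound 1 exceeds the scatter, so the three cannot be told apart here. Compound 4 `COc1ccc(-c2cc(/C=C/C(=O)c3ccc(N)cc3)[nH]n2)cc1OC` differs from compound 2 by hydrogen in place of methoxy on an aromatic carbon. For the measured compounds named here, no measured step matches this change; the only measured step, a number 4 percentage points higher from compound 2 to compound 3 (within the scatter), alters a different part of the molecule and was itself small. With all three numbers sitting near full activity, no movement beyond the scatter is expected, a step estimated as a number 2 percentage points higher from compound 2 to compound 4 (within the scatter). Compound 4 is therefore expected to give about 97%, within 88% to 106% in this assay.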

Compound 4, a percentage reported as activity, at one concentration (the size of the read-out at that concentration, not a potency): 97%
Beside the measured number, compound 4's estimate shows no gap at the digits printed; the range from low to high includes it.
By their numbers in this assay, from the lowest: compounds 2, 4, 3 and 1 (each within the scatter of the next).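

In this assay, hydrogen in place of methoxy on this aromatic carbon gives a number 2 percentage points higher from compound 2 to compound 4 (within the scatter), while methoxy in place of hydrogen gives a number 4 percentage points lower from compound 1 to compound 4 (within the scatter). For the compounds shown here, these are the first single-place readings of the methoxy groups on this ring, and neither change can be told from the scatter at the concentration tested. No measurement here offers an explanation for this. Still open, going by these compounds, is whether a hydroxyl group, a chlorine atom or an amine on this carbon would give a number beyond the scatter.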